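Replacing (2-methylcyclopropyl)carbonyl with 4-nitrophenyl

The source may report more compounds than this note shows. Statements on the series, on what has been measured and on what is new or still open speak of the compounds shown alone.

Among the compounds with values here, in an ADME assay on a cell-free system (plasma, Homo sapiens) for metabolic stability (a lower number here means that the compound disappears faster, a higher number that the compound lasts longer), compound 3 `CC1CC1C(=O)N1C(=O)[C@@H](C)[C@@H]2[C@@H]1CCN2C(=O)OCc1ccccc1` gives 2.6 h, the only actual number so far. Compound 1 `CNC(=O)N1C(=O)[C@@H](C)[C@@H]2[C@@H]1CCN2C(=O)OCc1ccccc1` gives > 24 h, which is a limit of the assay. Compound 2 `C[C@@H]1C(=O)N(c2ccc([N+](=O)[O-])cc2[N+](=O)[O-])[C@H]2CCN(C(=O)OCc3ccccc3)[C@H]12`, whose amide-type nitrogen in a ring also carries an aromatic ring, gives > 24 h, again a limit. Compound 4 `C[C@@H]1C(=O)N(c2ccc([N+](=O)[O-])cc2)[C@H]2CCN(C(=O)OCc3ccccc3)[C@H]12`, not yet measured, has 4-nitrophenyl in place of (2-methylcyclopropyl)carbonyl on that nitrogen (4-nitrophenyl in place of (2-methylcyclopropyl)carbonyl on an amide-type nitrogen in a ring). Within the data shown here, the one measured step bearing on this group is an at least 9.2-fold lower number from compound 1 to compound 3 (0.96 log units; beyond the scatter), which introduced it. Removing the group is therefore expected to raise the number, and the expected step is a 7.7-fold higher number from compound 3 to compound 4 (0.89 log units; beyond the scatter). The result may also land on (the limit of > 24 h in this assay, at which 2 of the 3 values shown sit). For compound 4 the estimate is 20 h, with an expected range of 8 h to 40 h.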

Compound 4, half-life: 40 h
Beside the measured number, compound 4's estimate is 2.0-fold (0.30 log units) below it; low and high end bracket the measured number.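

Swapping (2-methylcyclopropyl)carbonyl for 4-nitrophenyl on this amide-type nitrogen in a ring gives a 15-fold higher number from compound 3 to compound 4 (1.19 log units; beyond the scatter) in this assay. Both ends of this step are actual numbers, so it sizes a change at this position that the earlier step from compound 1 could only bound. The steps from compound 1 and compound 2 to compound 4 cannot be read, because both of those compounds sit at a limit: the limit of > 24 h in this assay, at which 2 of the 4 values shown sit.

Going by these compounds, it remains open whether the nitro group matters here, or whether plain phenyl or an aniline-type amine would last as long. On these data alone, whether an acetyl group on this nitrogen would behave like the group in compound 3 is also open.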